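Step from Compound 3 to Compound 4: Expected Cell Toxicity

A few compounds are considered here, and "the series" means these few. Any claim that something is new, unique, unknown or untested is made for them only; others in the source may bear on it.

Three compounds have been measured in a toxicity assay on GES1 cells (Homo sapiens) for inhibition, read by MTT assay, with a stated time of 72 h; on this read-out higher numbers stand for weaker inhibition and lower numbers for stronger inhibition:

Compound 1 `CCc1cc(N2CC[C@@H](C)[C@@H](N(C)c3ncnc4[nH]ccc34)C2)n2ncnc2n1` gives > 100000 nM, which is a limit of the assay.
Compound 2 `Cc1cc(N2CC[C@@H](C)[C@@H](N(C)c3ncnc4[nH]ccc34)C2)n2nc(SCc3cc(Cl)ccc3Cl)nc2n1` gives 87500 nM.
Compound 3 `Cc1cc(N2CC[C@@H](C)[C@@H](N(C)c3ncnc4[nH]ccc34)C2)n2nc(SCc3ccc(Cl)cc3)nc2n1` gives > 100000 nM, again a limit of the assay and not a number.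

Compound 3 therefore sits at the ceiling of what this assay reports, a ceiling described by the limit of > 100000 nM in this assay, at which 2 of the 3 values shown sit. Within the data shown here, the only measured step that touches compound 3 is an at least 1.1-fold higher number from compound 2 to compound 3 (0.05 log units; that floor lies within the scatter), and that step lies within the scatter, so compounds 2 and 3 cannot be told apart on these numbers.

Compound 4 `Cc1cc(N2CC[C@@H](C)[C@@H](N(C)c3ncnc4[nH]ccc34)C2)n2nc(SCCCc3ccccc3)nc2n1` differs from compound 3 in one place: phenethyl in place of 4-chlorophenyl on a saturated chain carbon bound to a sulfur. Among the measured compounds shown here, no measured step covers this particular exchange. For the measured compounds named here, the one step that exists, from compound 2 to compound 3, altered the group on the same saturated chain carbon bound to a sulfur and produced no change beyond the scatter, and all three measured compounds cluster at or near the assay's ceiling. On that basis no step beyond the scatter is expected, and compound 4 is estimated to give 100000 nM, within 50000 nM to 200000 nM, corresponding to an expected step of a number no higher from compound 3 to compound 4 (the limit leaves the size open), with a good chance that the assay again reports only a limit.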

Compound 4, half-maximal inhibitory concentration: > 100000 nM
Compound 4: no number, only a limit (the forecaster's own chance of this, stated with the estimate: 65%); the middle value sits exactly at the limit.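

In this assay compound 4 gives > 100000 nM, which is a limit of the assay and not a number, and since compound 3 also stands at a limit, the step between these two compounds cannot be read. The step that can be read is an at least 1.1-fold higher number from compound 2 to compound 4 (0.05 log units; that floor lies within the scatter), which lies within the scatter, so phenethyl in place of 2,5-dichlorophenyl on a saturated chain carbon bound to a sulfur gives no difference that these numbers can show. What is new is that this position, until now seen only with chlorine-bearing rings, also accepts a group with no chlorine and a different chain, 3-phenylpropyl, without leaving the top of the range that the assay reports: the limit of > 100000 nM in this assay, at which 3 of the 4 values shown sit.

With so many values at that limit, the compounds shown cannot rank these groups against each other or show how far the position could be changed before a readable number appears. From the compounds shown here alone, whether an amine or a carboxylic acid at the end of the chain on the sulfur would bring a compound down to a measurable value remains open.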